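Amino in place of chloro: from compound 2 to compound 4

This account rests on a few compounds, and the source may have more. Where it says the series, first, only, none or still open, it means among the compounds named here.

Compound 2 `OCC(CO)OCn1c(Cl)nc2c(Cl)c(Cl)ccc21` was tested in a functional assay on KB cells (Homo sapiens) for inhibition; on this read-out lower numbers stand for stronger inhibition and higher numbers for weaker inhibition. In this assay compound 2 gives only a limit, > 100000 nM. Compound 1 `OCC(CO)OCn1c(Cl)nc2cc(Cl)c(Cl)cc21` also stops at a limit, > 100000 nM. Compound 3 `OCC(CO)OCn1cnc2cc(Cl)c(Cl)cc21` likewise shows only a limit, > 100000 nM. The step that the two limits leave unreadable from compound 1 to compound 3 cannot be read, and the limit of > 100000 nM in this assay, at which 3 of the 3 values shown sit, sums up all three values. Compound 4 `Nc1nc2c(Cl)c(Cl)ccc2n1COC(CO)CO` differs from compound 2 by amino in place of chloro on an aromatic carbon. No measured step covers an amino for chloro exchange, so the shown numbers give no direction for it. Compound 4 is therefore expected to stay at the edge of the measurable range, estimated at 100000 nM with a range from 20000 nM to 300000 nM. The expected step of a number no higher from compound 2 to compound 4 (the limit leaves the size open) is thus no readable change.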

Compound 4, half-maximal inhibitory concentration: > 100000 nM
Compound 4 gave a limit, no number; the forecaster's own chance of this, stated with the estimate: 75%; the middle value sits exactly at the limit.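

Compound 4 stops at a limit, > 100000 nM, so the exchange between compound 2 and compound 4 gives no readable step. The compounds shown leave open how any of these changes affects inhibition, with every value at the same limit: the limit of > 100000 nM in this assay, at which 4 of the 4 values shown sit.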